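Working notes: methyl on the ring amine, cytotoxicity series

A few compounds are considered here, and "the series" means these few. Any claim that something is new, unique, unknown or untested is made for them only; others in the source may bear on it.

Two compounds carry values in an ADME assay on HL-60 cells (Homo sapiens) for cytotoxicity, read by resazurin assay, with a stated time of 72 h; on this read-out lower numbers stand for an effect already at smaller amounts and higher numbers for an effect only at larger amounts of compound. Compound 1 `O=C(NCCO)Nc1nc2cc(C(=O)c3ccccc3)ccc2[nH]1` is one of them. In this assay compound 1 reaches only the limit > 30000 nM, which is a bound of the assay and not a number. Compound 2 `Nc1nc2ccc(C(=O)c3ccccc3)cc2n1C[C@H]1CCCN1` is the other. In this assay compound 2 likewise gives only the limit > 30000 nM. Going by the values given here, compound 2 thus stands at the same limit as the one other value shown, and no number separates the two; what the series shows is the limit of > 30000 nM in this assay, at which 2 of the 2 values shown sit. Among the compounds with values here, no pair of measured compounds differs in a single place, so no measured step is available.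

Compound 3 `CN1CCC[C@@H]1Cn1c(N)nc2ccc(C(=O)c3ccccc3)cc21` is not yet measured. It differs from compound 2 by methyl in place of hydrogen on an amine nitrogen in a ring. With both shown values resting on the limit, no direction for the step can be read from the series, and the expected step is a number no higher from compound 2 to compound 3 (the limit leaves the size open), none beyond the usual scatter. Compound 3 is therefore expected near 30000 nM, within a range from 10000 nM to 90000 nM, most probably reported once more as a limit rather than a number.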

Compound 3, half-maximal effective concentration: > 30000 nM
Compound 3: a limit, no number; the forecaster's own chance of this, stated with the estimate: 75%; the middle value sits exactly at the limit.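

Compound 3 gives only a limit in this assay, as compound 2 does, so the change of methyl in place of hydrogen on an amine nitrogen in a ring cannot be read as a step between compound 2 and compound 3. The compounds shown leave open whether this methyl affects the read-out at all, because every value rests on one bound: the limit of > 30000 nM in this assay, at which 3 of the 3 values shown sit.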